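The source may report more compounds than this note shows. Statements on the series, on what has been measured and on what is new or still open speak of the compounds shown alone.

Measured compounds:
compound 1, `N#CN/C(=N\CCCNc1ccccc1[N+](=O)[O-])NCCCCOc1cccc(CN2CCCCC2)c1`, 7.85
compound 2, `N#CN/C(=N\CCNC(=O)c1ccccc1)NCCCCOc1cccc(CN2CCCCC2)c1`, 7.67
compound 3, `N#CN/C(=N\CCCCNC(=O)c1ccccc1)NCCCOc1cccc(CN2CCCCC2)c1`, 6.81

In a functional assay on cardiac atrium for antagonist activity at histamine H2 receptor (Cavia porcellus) (a lower number here means a less potent compound, a higher number a more potent compound, by a factor of ten per unit of this negative logarithm), compound 2 stands second highest of the three numbers. Its nearest neighbour is compound 1: the step of a number 0.18 log units lower from compound 1 to compound 2 (within the scatter) is within the scatter, so the two cannot be told apart. Compound 3 is the furthest from compound 2, and the two values show a gap beyond the scatter; compound 3 also differs from compound 2 in the chain lengths on both sides of the cyanoguanidine, so no single step is listed for that pair.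

Compound 4, `Cc1ccc(S(=O)(=O)NCC/N=C(\NC#N)NCCCCOc2cccc(CN3CCCCC3)c2)cc1`, differs from compound 2 by (4-methylphenyl)sulfonyl in place of benzoyl on an amine nitrogen. Going by the values given here, the one measured step that bears on this position is the exchange of the terminal group at the same amine nitrogen, from compound 1 to compound 2, which gave a number 0.18 log units lower from compound 1 to compound 2 (within the scatter), within the scatter. On that basis a further exchange of the terminal group at this nitrogen is expected to move this assay little, if at all; the estimated step of a number 0.17 log units lower from compound 2 to compound 4 (within the scatter) is taken as within the scatter, with a wider range to allow for the larger group entering. For compound 4 the estimate is 7.5, in the range 6.9 to 8.1.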

Compound 4, negative logarithm of the antagonist equilibrium constant: 7.29
Beside the measured number, compound 4's estimate is 0.21 log units above it, within the range that was stated.
By their numbers in this assay, from the lowest: compound 3; then compound 4; then compounds 2 and 1 (each within the scatter of the next).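

In this assay, the terminal group on this amine nitrogen does register: (4-methylphenyl)sulfonyl in place of benzoyl gives a number 0.38 log units lower from compound 2 to compound 4 (beyond the scatter), a modest step, whereas the earlier exchange at this end of the molecule, a number 0.18 log units lower from compound 1 to compound 2 (within the scatter), could not be told from repeat measurement. Taking ((4-methylphenyl)sulfonyl)amino in place of ((2-nitrophenyl)amino)methyl gives a number 0.56 log units lower from compound 1 to compound 4 (beyond the scatter), so this end of the series tolerates such exchanges with modest loss rather than being indifferent to them. No measurement at hand accounts for either step.

The step from compound 2 to compound 4 changes the linking carbonyl to a sulfonyl and adds the 4-methyl group together, so the two changes stay unseparated; a phenylsulfonyl or a 4-methylbenzoyl group on the same nitrogen would divide the step between them. Also open, as far as these compounds go, is whether the same exchange gives a step of similar size on a longer chain, and how a terminal carboxylic acid or a basic amine at this nitrogen would read in this assay.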